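Swapping the aryl group on the amide carbonyl of compound 1

This account rests on a few compounds, and the source may have more. Where it says the series, first, only, none or still open, it means among the compounds named here.

Compound 1, `Cc1ccc(C(=O)Nc2cc(Cl)ccc2OCC(=O)Nc2ccc(S(N)(=O)=O)cc2C)cc1`: 54200 nM
Compound 2, `COc1ccc(C(=O)Nc2cc(Cl)ccc2OCC(=O)Nc2ccc(S(N)(=O)=O)cc2C)cc1`: 69500 nM
Compound 3, `Cc1ccc(C)c(C(=O)Nc2cc(Cl)ccc2OCC(=O)Nc2ccc(S(N)(=O)=O)cc2C)c1`: 79700 nM

These three compounds were measured in a functional assay on C8166 cells (Homo sapiens) for cytotoxicity, read by MTT assay; on this read-out higher numbers stand for lower toxicity in this test and lower numbers for higher toxicity in this test. Compound 1 shows the lowest of the three numbers, yet both neighbours lie within the scatter: a 1.3-fold higher number from compound 1 to compound 2 (0.11 log units; within the scatter) and a 1.5-fold higher number from compound 1 to compound 3 (0.17 log units; within the scatter). Compound 4, `Cc1cc(S(N)(=O)=O)ccc1NC(=O)COc1ccc(Cl)cc1NC(=O)c1cc(Cl)cc(C#N)c1`, has not been measured. It differs from compound 1 in one place: 3-chloro-5-cyanophenyl in place of 4-methylphenyl on a carbonyl carbon. The steps that already exchange the aryl group on that carbonyl carbon, a 1.5-fold higher number from compound 1 to compound 3 (0.17 log units; within the scatter) and a 1.1-fold higher number from compound 2 to compound 3 (0.06 log units; within the scatter), stayed within the scatter. For compound 4 no step beyond the scatter is therefore expected, so a 1.1-fold higher number from compound 1 to compound 4 (0.04 log units; within the scatter) is the estimate. Compound 4 is expected to give 60000 nM, within the range 28000 nM to 130000 nM.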

Compound 4, half-maximal cytotoxic concentration: 131000 nM
Compound 4: the middle estimate sits 2.2-fold (0.34 log units) below what was measured; measured number outside the range, above it.
By their numbers in this assay, from the lowest: compounds 1, 2, 3 and 4 (each within the scatter of the next, the first and the last beyond it).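

Among these compounds, on this carbonyl carbon, the choice of aryl group can move the number beyond the scatter: 3-chloro-5-cyanophenyl in place of 4-methylphenyl gives (a 2.4-fold higher number from compound 1 to compound 4 (0.38 log units; beyond the scatter)), the first such step here. Compared with the other two aryl groups, the new group stays within the scatter (a 1.6-fold higher number from compound 3 to compound 4 (0.22 log units; within the scatter)) and (a 1.9-fold higher number from compound 2 to compound 4 (0.28 log units; within the scatter)). Nothing available explains the step from compound 1.

The compounds shown leave open whether the chloro or the cyano group alone would give the same step. Going by these compounds, how a phenyl carrying an amine or a carboxylic acid would read also remains open.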